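Imine analogues on HeLa: cytotoxicity outlook for compound 3

The source may report more compounds than this note shows. Statements on the series, on what has been measured and on what is new or still open speak of the compounds shown alone.

Among the compounds with values here, compound 2 `Fc1ccccc1/C=N/c1sc2c(c1-c1nc3ccccc3s1)CCC2` gives 355 ug/mL in an ADME assay on HeLa cells (Homo sapiens) for cytotoxicity, read by MTT assay, with a stated time of 72 h (on this read-out higher numbers stand for lower toxicity in this test and lower numbers for higher toxicity in this test), the lower of the two numbers so far. Compound 1 `Nc1sc2c(c1-c1nc3ccccc3s1)CCCC2` gives 475 ug/mL in this assay, a gap within the scatter, so no order between the two is claimed. Compound 3 `C(=C/c1ccccc1)\C=N\c1sc2c(c1-c1nc3ccccc3s1)CCC2` is not yet measured. It differs from compound 2 by 2-phenylethenyl in place of 2-fluorophenyl on a carbon with a double bond to nitrogen. Within the data shown here, no step between measured compounds informs this change, so for this assay no step beyond the scatter is expected in either direction. Compound 3 is estimated at 330 ug/mL, with a range of 180 ug/mL to 600 ug/mL. The step this estimate implies is expected to be a 1.1-fold lower number from compound 2 to compound 3 (0.03 log units; within the scatter).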

Compound 3, half-maximal cytotoxic concentration: 100 ug/mL
Estimate against measurement, compound 3: 3.3-fold (0.52 log units) above, and the stated range ends above it.
By their numbers in this assay, from the lowest: compound 3; then compounds 2 and 1 (each within the scatter of the next).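

On a carbon with a double bond to nitrogen, the group is not neutral in this assay: 2-phenylethenyl in place of 2-fluorophenyl gives a 3.6-fold lower number from compound 2 to compound 3 (0.55 log units; beyond the scatter), a modest step toward higher toxicity in this test. Within the data shown here, this is the first step that lies beyond the scatter, so this position can move the read-out. No measured evidence bears on the reason for this step.

Still open, as far as these compounds go, is whether the double bond outside aromatic rings matters, which 2-phenylethyl or unsubstituted phenyl at this position would test. Also open, from the compounds shown here alone, is how an amine or a carboxylic acid on the phenyl ring of 2-phenylethenyl would read in this assay.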